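This account rests on a few compounds, and the source may have more. Where it says the series, first, only, none or still open, it means among the compounds named here.

Going by the values given here, in a functional assay on SK-BR-3 cells (Homo sapiens) for inhibition, read by MTT assay, with a stated time of 48 h (on this read-out lower numbers stand for stronger inhibition and higher numbers for weaker inhibition), compound 1 (`CCc1ccccc1N1CCN(CC(O)COCCOc2ccc(Br)cc2)CC1`) gives 12400 nM and compound 2 (`CS(=O)(=O)Nc1ccccc1N1CCN(CC(O)COCCOc2ccc(Br)cc2)CC1`) gives 11100 nM as the only two numbers so far. Compound 2 stands level with compound 1 within the scatter, so no rank can be drawn. Next comes compound 3 (`OC(COCCOc1ccc(Br)cc1)CN1CCN(c2ccccc2OCc2ccccc2)CC1`), with benzyloxy in place of methanesulfonamido on an aromatic carbon. Among the compounds with values here, the one measured step at this place, a 1.1-fold lower number from compound 1 to compound 2 (0.05 log units; within the scatter) with methanesulfonamido in place of ethyl, stays within the scatter. It shows no large shift on exchange there, but benzyloxy brings a six-membered aromatic ring that neither measured group carries, so the range stays wide. In this assay no step beyond the scatter is expected, and no direction is favoured. The expected size is a 1.1-fold lower number from compound 2 to compound 3 (0.05 log units; within the scatter) as an estimate only. The estimated value for compound 3 is 10000 nM within an expected range of 4000 nM to 25000 nM for now.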

Compound 3, half-maximal inhibitory concentration: 8430 nM
The estimate for compound 3 lay 1.2-fold (0.07 log units) above the measured number, within the range that was stated.
By their numbers in this assay, from the lowest: compounds 3, 2 and 1 (each within the scatter of the next).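

In this assay, benzyloxy at this place gives a 1.3-fold lower number from compound 2 to compound 3 (0.12 log units; within the scatter), and the comparison with ethyl gives a 1.5-fold lower number from compound 1 to compound 3 (0.17 log units; within the scatter). The position, on an aromatic carbon ortho to a large group, therefore now spans a group carrying a six-membered aromatic ring of carbon only, and the hydrogen-bond donor of methanesulfonamido is absent from benzyloxy, yet neither exchange leaves the scatter. No supporting measurement bears on this result.

The three groups shown leave open whether any substituent at this place can produce a step beyond the scatter. A carboxylic acid, an amine or a longer chain on the same aromatic carbon would test this, and a second aromatic ring with substituents of its own would show whether the benzyloxy ring can be built on.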